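Swapping Fluoro for Chloro on a Benzyl Ring

The source may hold more compounds than are shown below. What is called first, only, known or untested is meant among the compounds shown, and "the series" means these compounds.

Three compounds share one core and differ in the groups attached to it. Compound 1 `CN1CCC[C@@H]1Cn1nc(Cc2cccc(F)c2)c2ccccc2c1=O` is tested in an assay for binding affinity to Alpha-1A adrenergic receptor (Homo sapiens) (a lower number here means a stronger inhibitor, a higher number a weaker inhibitor), and gives 50.1 nM. Compound 2 `CN(C)CCn1nc(Cc2ccc(Cl)cc2)c2ccccc2c1=O` gives 158 nM in this assay, and compound 3 `O=c1c2ccccc2c(Cc2ccc(Cl)cc2)nn1C1CCCN(Cc2ccc(OCCCN3CCCCCC3)cc2)CC1` gives 100 nM. Among these three numbers compound 1 has the lowest; compound 3 sits within the usual scatter of it, while compound 2 lies beyond that scatter.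

Compound 4 `CN1CCC[C@@H]1Cn1nc(Cc2cccc(Cl)c2)c2ccccc2c1=O` has not yet been measured. It differs from compound 1 by chloro in place of fluoro on an aromatic carbon, a small exchange of one halogen for another on an aromatic carbon of a six-membered aromatic ring of carbon only. No measured pair among these compounds shows such an exchange, so there is no direct precedent to lean on. The expectation is that the step of a 1.1-fold lower number from compound 1 to compound 4 (0.05 log units; within the scatter) stays within the scatter, with no clear direction. Compound 4 is expected to give about 45 nM in this assay, most likely between 15 nM and 140 nM.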

Compound 4, inhibition constant: 398 nM
Estimate against measurement, compound 4: 8.8-fold (0.95 log units) below; measured number above the stated range.
By their numbers in this assay, from the lowest: compounds 1, 3 and 2 (each within the scatter of the next, the first and the last beyond it); then compound 4.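

Among these compounds, until now no two compounds differed in a single place, so this pair gives the first direct reading of how this assay responds to a change on the benzyl ring. The exchange of 3-fluorobenzyl for 3-chlorobenzyl swaps one heavy atom for another, with no change in hydrogen-bond donors, acceptors or net charge, yet it gives a 7.9-fold higher number from compound 1 to compound 4 (0.90 log units; beyond the scatter) and this step lies beyond the scatter, so even a small halogen exchange at this position can matter. No measurement shown here explains the weaker binding.

From the compounds shown here alone, it remains open whether a hydrogen, a methyl or a methoxy group at this position would sit nearer compound 1 or compound 4. A single pair also cannot tell whether the same exchange would have as large an effect with a different side chain on the core.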